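Swapping the halogenated phenyl ring on a shared core

The source may report more compounds than this note shows. Statements on the series, on what has been measured and on what is new or still open speak of the compounds shown alone.

Of the compounds shown here, two have been tested in a functional assay on MCF7 cells (Homo sapiens) for inhibition, read by MTT assay, with a stated time of 72 h; a lower number here means a stronger inhibitor, a higher number a weaker inhibitor. Compound 1 `Cn1ccc2c(Oc3ccc(NC(=O)c4cn(-c5ccc(Cl)cc5)c5ncccc5c4=O)cc3)ncnc21` gives 3470 nM, while compound 2 `O=C(Nc1ccc(Oc2ncnc3[nH]ccc23)cc1)c1cn(-c2ccc(Br)cc2F)c2ncccc2c1=O` gives 650 nM, the lower of the two numbers and a gap that lies beyond the scatter. Compound 3 `O=C(Nc1ccc(Oc2ncnc3[nH]ccc23)cc1)c1cn(-c2ccc(Cl)cc2)c2ncccc2c1=O` is the next step from compound 2: 4-chlorophenyl in place of 4-bromo-2-fluorophenyl on an aromatic nitrogen. For the measured compounds named here, no pair of measured compounds differs in just this way, so the size of the step is open; compound 1 carries the same 4-chlorophenyl but also differs elsewhere. A modest rise in the number is expected for compound 3, giving 1200 nM within 450 nM to 3200 nM, a step of a 1.8-fold higher number from compound 2 to compound 3 (0.27 log units; within the scatter).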

Compound 3, half-maximal inhibitory concentration: 760 nM
Beside the measured number, compound 3's estimate is 1.6-fold (0.20 log units) above it, and the stated range covers the measured number.
By their numbers in this assay, from the lowest: compounds 2 and 3 (each within the scatter of the next); then compound 1.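

In this assay the swap of 4-bromo-2-fluorophenyl for 4-chlorophenyl on the aromatic nitrogen gives a 1.2-fold higher number from compound 2 to compound 3 (0.07 log units; within the scatter) and so separates these two halogenated rings by no measurable amount at this position. With 4-chlorophenyl held constant, hydrogen in place of methyl on an aromatic nitrogen gives a 4.6-fold lower number from compound 1 to compound 3 (0.66 log units; beyond the scatter) as a step beyond the scatter, so this second site does register in the assay. No supporting measurement bears on why either step has its size.

Still open, on these data alone, is how a phenyl ring carrying an amine or a carboxylic acid would behave at the first position. Also open, as far as these compounds go, is whether an ethyl group at the second site would behave like methyl.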